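A few compounds are considered here, and "the series" means these few. Any claim that something is new, unique, unknown or untested is made for them only; others in the source may bear on it.

Working notes on the series. Of the compounds shown here, three of the shared core have been measured in an assay for inhibition of 15-hydroxyprostaglandin dehydrogenase [NAD(+)] (Homo sapiens), read by fluorescence, with a stated time of 15 min, in the presence of a further agent that is not named here; a lower number here means a stronger inhibitor, a higher number a weaker inhibitor. Compound 1 `Nc1c([S+]([O-])CCCF)sc2nc(-c3cccs3)cc(-c3ccccc3)c12` gives 6.1 nM; compound 2 `CCC[S+]([O-])c1sc2nc(-c3cccs3)cc(-c3ccccc3)c2c1N` gives 2.1 nM; compound 3 `Nc1c([S+]([O-])CCCCl)sc2nc(-c3cccs3)cc(-c3ccccc3)c12` gives 4 nM. On these numbers compound 3 stands second highest of the three: its value sits within the scatter of both compound 1 and compound 2, so no order among them can be claimed.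

The next compound, compound 4 `CCCCS(=O)(=O)c1sc2nc(-c3cccs3)cc(-c3ccccc3)c2c1N`, differs from compound 3 in one place: a group of 7 heavy atoms (4 carbon, 2 oxygen, 1 sulfur; no ring) in place of a group of 6 heavy atoms (3 carbon, 1 oxygen, 1 sulfur, 1 chlorine; no ring), on an aromatic carbon.

Among the compounds with values here, none of the measured steps covers the change of the sulfur-bearing group itself; they only touch the chain end. Within the data shown here, the step of a 2.9-fold lower number from compound 1 to compound 2 (0.46 log units; beyond the scatter) is the one step beyond the scatter, while a 1.5-fold lower number from compound 1 to compound 3 (0.18 log units; within the scatter) and a 1.9-fold higher number from compound 2 to compound 3 (0.28 log units; within the scatter) stay within it. Removing the chloro, taken on its own, is thus covered by a step within the scatter, and the change from the sulfur-bearing group with one oxygen to butylsulfonyl is not covered at all. The expectation for the step from compound 3 to compound 4 is therefore a 1.1-fold lower number from compound 3 to compound 4 (0.06 log units; within the scatter), with no direction asserted beyond the scatter. For compound 4 the estimated value in this assay is 3.5 nM, with a range from 1 nM to 12 nM.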

Compound 4, half-maximal inhibitory concentration: 25 nM
Compound 4: the middle estimate sits 7.1-fold (0.85 log units) below what was measured, outside the stated range (above it).
By their numbers in this assay, from the lowest: compounds 2, 3 and 1 (each within the scatter of the next, the first and the last beyond it); then compound 4.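

In this assay, butylsulfonyl on the aromatic carbon next to the ring sulfur gives a higher number than each of the three groups with one oxygen on sulfur, and every step lies beyond the scatter (a 6.3-fold higher number from compound 3 to compound 4 (0.80 log units; beyond the scatter); a 4.1-fold higher number from compound 1 to compound 4 (0.61 log units; beyond the scatter); a 12-fold higher number from compound 2 to compound 4 (1.08 log units; beyond the scatter)). Changes at the chain end among the earlier compounds reached only (a 2.9-fold lower number from compound 1 to compound 2 (0.46 log units; beyond the scatter)), whereas these new steps show that replacing the whole sulfur-bearing group moves the number further, making compound 4 the weakest inhibitor of the four. No measurement shown bears on the reason for this rise.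

The step from compound 2 to compound 4 changes both the chain and the oxidation state of the sulfur, so the shown values cannot assign the rise to either change; a propylsulfonyl group or a butyl chain on a sulfur with one oxygen at this carbon would separate the two. Also open, as far as these compounds go, is how a sulfonamide or a longer chain on the sulfonyl group would read at this position.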